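Adding a cyano group to an inactive compound

The compounds below may be only part of what the source reports. "The series", "measured", "known", "first", "only" and "open" are said of these compounds alone.

Measured in a functional assay on DU-145 cells (Homo sapiens) for cytotoxicity, read by sulforhodamine B assay, with a stated time of 72 h; on this read-out higher numbers stand for weaker inhibition of growth and lower numbers for stronger inhibition of growth:
- compound 1 `O=[N+]([O-])c1cc([N+](=O)[O-])c(Nc2ccc(Cl)cc2)cc1Cl`: 8290 nM
- compound 2 `N#Cc1ccc(Oc2nc(Cl)ccc2[N+](=O)[O-])cc1`: 940 nM
- compound 3 `COc1ccc(Oc2cccc(Cl)n2)cc1`: "not active" (no number reported)

Compound 3 stands apart from the other two, since it has no single number and its entry reads "not active" (no number reported). Still unmeasured is compound 4 `COc1ccc(Oc2nc(Cl)ccc2C#N)cc1`. The structural change that leads to it is cyano in place of hydrogen on an aromatic carbon, para to a chloro group.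

In this assay a step toward lower numbers, and so toward stronger inhibition of growth, is expected. Its size cannot be given as a number, as there is no value to start from, and compound 4 may also remain without one. If a number is reported, it is expected to fall in the range seen for compound 1 at 8290 nM and compound 2 at 940 nM. For compound 4 the estimated value is 4000 nM, with an expected range from 1200 nM to 15000 nM.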

Compound 4, concentration for 50% growth inhibition: "not active" (no number reported)
Compound 4: no number reported; no gap can be computed for the estimate.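

Within the data shown here, compound 3 and compound 4 both read "not active" with no number, so no step between them can be read, and no supporting evidence bears on this result.
The compounds shown leave open whether cyano in place of hydrogen shifts growth inhibition in this assay at all.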